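This account rests on a few compounds, and the source may have more. Where it says the series, first, only, none or still open, it means among the compounds named here.

Measured in a functional assay on A549 cells (Homo sapiens) for cytotoxicity, read by MTT assay, with a stated time of 48 h; a lower number here means a stronger inhibitor, a higher number a weaker inhibitor:
- Compound 1 `C=C1CCC[C@]2(C)CCC(c3cn(-c4ccc(C(C)=O)cc4)nn3)=CC[C@@]12C`: 46400 nM
- Compound 2 `C=C1CCC[C@]2(C)CCC(c3cn(-c4cccc([N+](=O)[O-])c4)nn3)=CC[C@@]12C`: 24700 nM
- Compound 3 `C=C1CCC[C@]2(C)CCC(c3cn(CC(=O)Nc4ccc(C)cc4)nn3)=CC[C@@]12C`: 270000 nM

Compound 1, at 46400 nM, lies within the usual scatter of compound 2, so these two cannot be told apart in this assay. Compound 3, at 270000 nM, gives a clearly higher number than either of them, which means a weaker effect on the cells.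

The next compound to be tested is compound 4 `C=C1CCC[C@]2(C)CCC(c3cn(-c4ccc(C)cc4)nn3)=CC[C@@]12C`. It keeps the shared core of compound 1 and changes in one place, with methyl in place of acetyl on an aromatic carbon, para to a large group: methyl in place of acetyl on an aromatic carbon. The same difference can be read as 4-acetylphenyl to 4-methylphenyl.

Among the compounds with values here, only one measured step bears on this change. Placing 3-nitrophenyl where compound 1 has 4-acetylphenyl gave a 1.9-fold lower number from compound 1 to compound 2 (0.27 log units; within the scatter). That is one exchange of this aromatic group, and it did not move the number beyond the scatter. Compound 3 is linked to compound 1 by no single change, so it offers no direct guide. No step beyond the scatter is therefore expected here, though a single step is thin evidence.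

The expected result is a 1.2-fold lower number from compound 1 to compound 4 (0.06 log units; within the scatter). For compound 4 the estimated value is 40000 nM, with an expected range of 16000 nM to 100000 nM.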

Compound 4, half-maximal inhibitory concentration: 58800 nM
Estimate against measurement, compound 4: 1.5-fold (0.17 log units) below, within the range that was stated.
By their numbers in this assay, from the lowest: compounds 2, 1 and 4 (each within the scatter of the next, the first and the last beyond it); then compound 3.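

In this assay, replacing acetyl with methyl on this aromatic carbon, para to a large group, gives a 1.3-fold higher number from compound 1 to compound 4 (0.10 log units; within the scatter): losing the carbonyl, and with it the hydrogen-bond acceptor of acetyl, does not produce a change that can be told from the scatter. The other new comparison gives a 2.4-fold higher number from compound 2 to compound 4 (0.38 log units; beyond the scatter), a modest step and the first among these aryl compounds to pass beyond the scatter, although it alters both the substituent and the place it occupies on the ring, so neither alteration can be credited with the difference on its own. No measurement shown here explains either step.

As far as these compounds go, what remains open is whether the gap between compound 2 and compound 4 follows the nitro and methyl groups themselves or the carbon that carries them, a question that a single comparison of this kind cannot settle. It is also unknown whether the tolerance seen for acetyl and methyl extends to quite different groups on the same carbon, such as an amine, a carboxylic acid or a longer chain.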